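A few compounds are considered here, and "the series" means these few. Any claim that something is new, unique, unknown or untested is made for them only; others in the source may bear on it.

Compound 3 `COc1ccc(CCCNCc2c(OC)cc(Oc3cccc(Nc4ccccc4)c3)cc2OC)cc1` gives the lowest number of the three measured compounds in a functional assay on HCT-15 cells (Homo sapiens) for inhibition, read by MTT assay, with a stated time of 72 h (on this read-out lower numbers stand for stronger inhibition and higher numbers for weaker inhibition), at 730 nM. Compound 2 `COc1ccc(CNCc2c(OC)cc(Oc3cccc(Nc4ccccc4)c3)cc2OC)cc1` gives 2650 nM and compound 1 `COc1cc(Oc2cccc(Nc3ccccc3)c2)cc(OC)c1CNCc1ccc(C)cc1` gives 5400 nM. The steps of a 7.4-fold lower number from compound 1 to compound 3 (0.87 log units; beyond the scatter) and a 3.6-fold lower number from compound 2 to compound 3 (0.56 log units; beyond the scatter) both point the same way, as does a 2.0-fold lower number from compound 1 to compound 2 (0.31 log units; beyond the scatter). Compound 4 `COc1cc(Oc2cccc(Nc3ccccc3)c2)cc(OC)c1CN(C)C` differs from compound 3 by dimethylamino in place of (3-(4-methoxyphenyl)propyl)amino on a saturated chain carbon bound to an aromatic carbon. Both measured steps into compound 3 lowered the number in this assay, and compound 4 gives up the whole arylalkyl substituent that those steps brought in, so a step upward beyond the scatter is expected, an 11-fold higher number from compound 3 to compound 4 (1.04 log units; beyond the scatter). Compound 4 is therefore estimated at 8000 nM, with a range from 2500 nM to 25000 nM.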

Compound 4, half-maximal inhibitory concentration: 15600 nM
Estimate against measurement, compound 4: 2.0-fold (0.29 log units) below; low and high end bracket the measured number.
By their numbers in this assay, from the lowest: compound 3; then compound 2; then compound 1; then compound 4.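

Removing the ring-bearing amine substituent raises the number whichever of the three it replaces: a 2.9-fold higher number from compound 1 to compound 4 (0.46 log units; beyond the scatter), a 5.9-fold higher number from compound 2 to compound 4 (0.77 log units; beyond the scatter) and a 21-fold higher number from compound 3 to compound 4 (1.33 log units; beyond the scatter). At this place, then, compound 4, with dimethylamino, which has no ring and no hydrogen-bond donor, stands above all three compounds that carry an aromatic ring on the amine.

The change removes the ring and the donor together, so the compounds shown do not separate the two; methylamino or a butyl chain ending in 4-methoxyphenyl would bear on this. No measurement shown explains the rise.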